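The source may report more compounds than this note shows. Statements on the series, on what has been measured and on what is new or still open speak of the compounds shown alone.

Compound 1 `O=C(/C=C/c1ccccc1F)c1ccc[nH]1` was tested in an assay for inhibition of cytochrome P450 1A1 (Homo sapiens), read by fluorescence, using microsomes, with a stated time of 10 min; on this read-out lower numbers stand for stronger inhibition and higher numbers for weaker inhibition. In this assay compound 1 gives only a limit, > 20000 nM. Compound 2 `O=C(/C=C/c1cccc(Cl)c1)c1ccc[nH]1` gives 16000 nM in this assay. Compound 3 `O=C(/C=C/c1cc([N+](=O)[O-])ccc1Cl)c1ccc[nH]1` also stops at a limit in this assay, > 20000 nM. Compound 1 thus stands at the limit of > 20000 nM in this assay, at which 2 of the 3 values shown sit, which is a limit rather than a number, so no order among these three compounds can be read from it. Within the data shown here, no two of the measured compounds differ in a single place, so no measured step exists to guide an expectation.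

The change from compound 1 to compound 4 `COc1ccccc1/C=C/C(=O)c1ccc[nH]1` is methoxy in place of fluoro on an aromatic carbon. With every measured value weak or at the limit, the expectation is that compound 4 stays weak in this assay, and the step of an at least 1.3-fold lower number from compound 1 to compound 4 (0.12 log units; that floor lies within the scatter) is estimated as small, not clearly beyond the scatter, in either direction. Compound 4 is expected to give about 15000 nM, within 4000 nM to 40000 nM, with a fair chance that this assay again reports only a limit.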

Compound 4, half-maximal inhibitory concentration: 900 nM
Beside the measured number, compound 4's estimate is 17-fold (1.22 log units) above it; measured number outside the range, below it.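

Putting methoxy in place of fluoro on this aromatic carbon, ortho to a group of 9 heavy atoms, gives an at least 22-fold lower number from compound 1 to compound 4 (1.34 log units; beyond the scatter) in this assay, the first change shown to move the read-out clearly beyond the scatter. Compound 1 gives only a limit, > 20000 nM. The step is therefore a floor and not an exact size, because its starting point is a limit rather than a number: the limit of > 20000 nM in this assay, at which 2 of the 4 values shown sit.

As far as these compounds go, whether a hydroxyl group, an ethoxy group or a dimethylamino group on the same carbon would give a similar result stays open, as does whether methoxy would act alike on another carbon of this ring. The compounds shown also leave open why this one change matters so much, and whether the step would look the same on another enzyme.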